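The compounds below may be only part of what the source reports. "The series", "measured", "known", "first", "only" and "open" are said of these compounds alone.

Measured compounds:
compound 1, `Cc1c(OCCCCOc2ccc(C(=O)CC(C)(C)C)c(O)c2C)cccc1C(=O)O`: 89%
compound 2, `CCCC(=O)c1ccc(OCCCCOc2cc(C(=O)O)ccc2OC)c(C)c1O`: 78%
compound 3, `Cc1cc(OCCCCOc2ccc(C(=O)CC3CCCC3)c(O)c2C)ccc1C(=O)O`: 114%

These three compounds were tested in an ADME assay on a cell-free system (plasma, Rattus norvegicus) for metabolic stability, read by LC-MS, with a stated time of 60 min, tested at 100 uM; on this read-out lower numbers stand for a less stable compound and higher numbers for a more stable compound. Compound 1 gives 89% in this assay, the second highest of the three numbers. Its nearest neighbour is compound 2, whose 78% lies lower by a margin beyond the usual scatter; furthest away is compound 3, whose 114% lies higher, again beyond the scatter. All three share the same core.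

Compound 4, `Cc1c(OCCCCOc2ccc(F)c(C(=O)O)c2)ccc(C(=O)CC(C)(C)C)c1O`, has not yet been measured in this assay. It differs from compound 1 in a single place: 3-carboxy-4-fluorophenyl in place of 3-carboxy-2-methylphenyl on an oxygen on a saturated carbon. Ring, donor and acceptor counts stay the same; one carbon gives way to one fluorine.

Going by the values given here, no measured pair shows this change, so the size of the step can only be estimated. Compound 1 already gives 89% in this assay, and the change is small. The expected step from compound 1 to compound 4 is therefore a number 1 percentage points lower from compound 1 to compound 4 (within the scatter), none beyond the scatter. For compound 4 the estimate is 88%, with a range from 70% to 105%.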

Compound 4, percent of the compound remaining: 83%
Beside the measured number, compound 4's estimate is 5 percentage points above it, and the stated range covers the measured number.
By their numbers in this assay, from the lowest: compounds 2, 4 and 1 (each within the scatter of the next, the first and the last beyond it); then compound 3.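

In this assay, going by these compounds alone, swapping the 3-carboxy-2-methylphenyl group on an oxygen on a saturated carbon for a 3-carboxy-4-fluorophenyl group gives a number 6 percentage points lower from compound 1 to compound 4 (within the scatter), the first step here that can be read for a change in one place. At this position, then, this exchange of one substituted ring for another leaves the result within the usual scatter, so the two compounds cannot be told apart in this assay. No measurement shown offers an explanation for this result.

The compounds shown leave open what a nitrile or a primary amide in place of the carboxylic acid on this ring would give, and what chlorine in place of the fluorine would give. They also leave open whether the same exchange would give a similar step on the core of compound 3.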